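Halogen Swap on an Aryl Group Without Measured Potency

The source may report more compounds than this note shows. Statements on the series, on what has been measured and on what is new or still open speak of the compounds shown alone.

The study gathers compounds around a shared core and tests them in a functional assay on BMDM cells (Mus musculus, strain C57BL/6) for inhibition, with a stated time of 2 days; a lower number here means a stronger inhibitor, a higher number a weaker inhibitor. Compound 1 `COc1ccc(-c2cn(CC(=O)Nc3cc(C)on3)nn2)cc1` gives only the limit > 30000 nM in this assay, not a number. Compound 2 `Cc1cc(NC(=O)Cn2cc(-c3ccccc3Cl)nn2)no1` likewise reaches only the limit > 30000 nM in this assay. Among the compounds with values here, compound 2 therefore stands at the limit of > 30000 nM in this assay, at which 2 of the 2 values shown sit, and no measured step between compounds is available to place it more finely. Compound 3 `Cc1cc(NC(=O)Cn2cc(-c3ccc(F)cc3)nn2)no1` has not yet been measured; it differs from compound 2 by 4-fluorophenyl in place of 2-chlorophenyl on an aromatic carbon. With both measured compounds sitting at a limit, the numbers give no sign of either a gain or a loss from that change, so the expected step of a number no higher from compound 2 to compound 3 (the limit leaves the size open) is none beyond the scatter, and a further limit is the likeliest outcome. Compound 3 is accordingly estimated at 30000 nM in this assay, within a range from 8000 nM to 100000 nM.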

Compound 3, half-maximal inhibitory concentration: > 30000 nM
Compound 3 ended at the assay's limit; the forecaster's own chance of this, stated with the estimate: 75%; the middle value sits exactly at the limit.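

Compound 3 gives > 30000 nM in this assay as a limit and not a number. The steps to it from compound 1 and compound 2 cannot be read, and the three compounds stand together: the limit of > 30000 nM in this assay, at which 3 of the 3 values shown sit. The compounds shown leave open whether these aryl groups on the shared core differ at all in inhibition.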